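A few compounds are considered here, and "the series" means these few. Any claim that something is new, unique, unknown or untested is made for them only; others in the source may bear on it.

Notes on the series in an assay on cell membranes for displacement of a labelled ligand from Neuronal acetylcholine receptor; alpha4/beta2 (Rattus norvegicus); a higher number here means a weaker inhibitor, a lower number a stronger inhibitor. Compound 1 `COC1=NOC2(CCC[N+](C)(C)C2)C1` carries a methoxy group on the five-membered ring and a quaternary nitrogen in the other ring; in this assay compound 1 gives 94000 nM. Compound 3 `C[N+]1(C)CCCC2(CC(Br)=NO2)C1` differs from compound 1 by bromo in place of methoxy on a carbon with a double bond to nitrogen, with the step of a 1.9-fold lower number from compound 1 to compound 3 (0.27 log units; within the scatter). In this assay compound 3 gives 50000 nM. Compound 2 `COC1=NOC2(CCCN(C)C2)C1` has a core with an uncharged methylated ring nitrogen; how its core differs from that of compound 1 is not broken down here. In this assay compound 2 gives > 100000 nM, which is a limit of the assay and not a number. Compound 4 `CN1CCCC2(CC(Br)=NO2)C1` is the one still to be measured; it differs from compound 2 by bromo in place of methoxy on a carbon with a double bond to nitrogen, the same change as that from compound 1 to compound 3, at the same place. The expected step is a step that the limit leaves unreadable from compound 2 to compound 4, set beside the earlier one. That expectation rests on the measured step of a 1.9-fold lower number from compound 1 to compound 3 (0.27 log units; within the scatter), which stayed within the scatter, and on compound 2 sitting at the limit of > 100000 nM in this assay, at which 1 of the 3 values shown sits. Compound 4 is therefore estimated at 120000 nM, with a range from 40000 nM to 400000 nM, and a fair chance that only a limit is reported again.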

Compound 4, inhibition constant: 44000 nM
For compound 4 the middle estimate is 2.7-fold (0.44 log units) above the measured one; the measured number falls inside the stated range.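

In this assay, bromo in place of methoxy on a carbon with a double bond to nitrogen gives an at least 2.2-fold lower number from compound 2 to compound 4 (0.35 log units; beyond the scatter), so on this core the change is seen beyond the scatter, with compound 4 at 44000 nM. The value of compound 2 is a limit of the assay and not a number, so this step has a lower bound but no fixed size: the limit of > 100000 nM in this assay, at which 1 of the 4 values shown sits. The change can thus be carried to the second core as a step that is at least modest, but this does not show that it has the same size on both cores or a different one: the same change on two cores in this assay, a 1.9-fold lower number (0.27 log units; within the scatter) from compound 1 to compound 3 and an at least 2.2-fold lower number (0.35 log units; beyond the scatter) from compound 2 to compound 4; the limit leaves it open whether they differ.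

On these data alone, each core contributes a single pair, with only methoxy and bromo at this place, so any wider trend across substituents remains open. As far as these compounds go, whether chloro or an amine at the same place would follow bromo on both cores, and whether an ethyl group on the ring nitrogen would alter the step, also remains open.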